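The source may hold more compounds than are shown below. What is called first, only, known or untested is meant among the compounds shown, and "the series" means these compounds.

Measured compounds:
- compound 1 `Cc1cc(CNCc2ccc(Cl)cc2)c(C)n1-c1ccc(Cl)cc1`: 18 ug/mL
- compound 2 `Cc1cc(CNCc2ccccc2)c(C)n1-c1ccc(Cl)cc1`: 7.2 ug/mL
- compound 3 `Cc1c(CNC2CCCCC2)cc(-c2ccc(Cl)cc2)n1-c1ccc(Cl)cc1`: 3.9 ug/mL

In an ADME assay on THP-1 cells (Homo sapiens) for cytotoxicity, read by trypan blue exclusion, with a stated time of 48 h (on this read-out lower numbers stand for stronger inhibition of growth and higher numbers for weaker inhibition of growth), compound 3 holds the lowest of the three numbers; its gap to compound 2 lies within the scatter, while its gap to compound 1 lies beyond it. Compound 4 `Cc1cc(CNC2CCCCC2)c(C)n1-c1ccc(Cl)cc1` differs from compound 3 by methyl in place of 4-chlorophenyl on an aromatic carbon. Among the compounds with values here, the only measured step, a 2.5-fold lower number from compound 1 to compound 2 (0.40 log units; beyond the scatter), concerns a different change and does not bear on this exchange. Within the data shown here, no measured pair reports this change, so the direction of any shift is unknown. Compound 4 is therefore expected to give a number close to that of compound 3, with a 1.5-fold higher number from compound 3 to compound 4 (0.19 log units; within the scatter) likely within the scatter. Compound 4 is estimated at 6 ug/mL, with a range from 2.5 ug/mL to 15 ug/mL.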

Compound 4, concentration for 50% growth inhibition: 7.4 ug/mL
The estimate for compound 4 lay 1.2-fold (0.09 log units) below the measured number, and the stated range covers the measured number.
By their numbers in this assay, from the lowest: compounds 3, 2 and 4 (each within the scatter of the next); then compound 1.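

In this assay the step of a 1.9-fold higher number from compound 3 to compound 4 (0.28 log units; within the scatter) shows that, at this place next to the ring nitrogen, methyl can stand in for 4-chlorophenyl with no shift beyond the scatter. With methyl there, the amine nitrogen carries cyclohexyl in place of benzyl with a 1.0-fold higher number from compound 2 to compound 4 (0.01 log units; within the scatter) and so stays within the scatter. Cyclohexyl in place of 4-chlorobenzyl gives a 2.4-fold lower number from compound 1 to compound 4 (0.39 log units; beyond the scatter) and is the only one of these steps beyond it. From the compounds shown here alone, what an amine, a carboxylic acid or a longer chain would give at this place stays open. No measurement at hand explains these numbers.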